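Two Inactive Thioureas and a Methoxy Variant

A few compounds are considered here, and "the series" means these few. Any claim that something is new, unique, unknown or untested is made for them only; others in the source may bear on it.

Compound 1 (`CNC(=O)c1ccc(Oc2cccc(NC(=S)Nc3ccc(C)c(C)c3)c2)nc1`): > 100000 nM
Compound 2 (`CNC(=O)c1ccc(Oc2cccc(NC(=S)Nc3ccc(OC(F)(F)F)cc3)c2)nc1`): > 100000 nM

Both numbers come from a functional assay on HepG2 cells (Homo sapiens) for antiproliferative activity, read by MTT assay; a higher number here means a weaker inhibitor, a lower number a stronger inhibitor. For compound 1 the value is a limit of the assay, not a measured number. The same holds for compound 2. Both stand at the limit of > 100000 nM in this assay, at which 2 of the 2 values shown sit, so compound 1 shows no measurable activity here. Compound 3, `CNC(=O)c1ccc(Oc2cccc(NC(=S)Nc3ccc(OC)cc3)c2)nc1`, differs from compound 1 by 4-methoxyphenyl in place of 3,4-dimethylphenyl on an amide-type nitrogen. Within the data shown here, no step between measured compounds is known, so the expected step that the limit leaves unreadable from compound 1 to compound 3 in this assay is none beyond the usual scatter. Compound 3 is expected to give 150000 nM, between 50000 nM and 500000 nM, most likely again as a limit only.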

Compound 3, half-maximal inhibitory concentration: 85300 nM
Beside the measured number, compound 3's estimate is 1.8-fold (0.25 log units) above it; low and high end bracket the measured number.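

Among these compounds, compound 3 gives this series a readable number on the amide-type nitrogen, where the earlier compounds gave only limits. In this assay, 4-methoxyphenyl in place of 3,4-dimethylphenyl gives an at least 1.1-fold lower number from compound 1 to compound 3 (0.06 log units; that floor lies within the scatter), and methyl in place of trifluoromethyl on the oxygen gives an at least 1.1-fold lower number from compound 2 to compound 3 (0.06 log units; that floor lies within the scatter). The true size of both steps cannot be read because the other two compounds stand at a limit: the limit of > 100000 nM in this assay, at which 2 of the 3 values shown sit.

From the compounds shown here alone, what a 4-aminophenyl or a 4-ethoxyphenyl group would give on the same nitrogen remains open.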